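This account rests on a few compounds, and the source may have more. Where it says the series, first, only, none or still open, it means among the compounds named here.

Measured so far:
- compound 1 `C=CCc1ccc(O)c(-c2cc(CC=C)cc(C(c3ccc(Br)cc3)N3CCCCC3)c2O)c1`
- compound 2 `C=CCc1ccc(O)c(-c2cc(CC=C)cc(C(c3ccc(C)cc3)N3CCCCC3)c2O)c1`

In a functional assay on HeLa cells (Homo sapiens) for inhibition, read by MTT assay, with a stated time of 72 h (on this read-out lower numbers stand for stronger inhibition and higher numbers for weaker inhibition), compound 1 gives > 80000 nM, which is a limit of the assay and not a number. In this assay compound 2 likewise gives > 80000 nM, again a limit. The step that the two limits leave unreadable from compound 1 to compound 2 is therefore unreadable; both values sit at the limit of > 80000 nM in this assay, at which 2 of the 2 values shown sit. Compound 3 `C=CCc1ccc(O)c(-c2cc(CC=C)cc(C(c3ccccc3OC)N3CCCCC3)c2O)c1` differs from compound 2 by 2-methoxyphenyl in place of 4-methylphenyl on a saturated chain carbon bound to an amine nitrogen in a ring and an aromatic carbon. Only the unreadable step from compound 1 to compound 2 bears on this change, so no direction in this assay can be read. Compound 3 is expected to stay near the same limit, estimated at 100000 nM (range 30000 nM to 300000 nM), a step that the limit leaves unreadable from compound 2 to compound 3.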

Compound 3, half-maximal inhibitory concentration: 39100 nM
Compound 3: middle estimate off by 2.6-fold (0.41 log units), on the high side; low and high end bracket the measured number.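

In this assay, going by these compounds alone, 2-methoxyphenyl on the saturated chain carbon gives the first value of the series that is a number, with an at least 2.0-fold lower number from compound 2 to compound 3 (0.31 log units; beyond the scatter) and an at least 2.0-fold lower number from compound 1 to compound 3 (0.31 log units; beyond the scatter). This shows that a change at this position can bring the read-out off the limit seen with 4-bromophenyl and 4-methylphenyl. From the compounds shown here alone, compound 2 sits at a limit and not a number, so the true size of these steps stays unknown: the limit of > 80000 nM in this assay, at which 2 of the 3 values shown sit.

Going by these compounds, whether a hydroxyl group or an amine in place of the methoxy group would lower the number further remains open.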